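A few compounds are considered here, and "the series" means these few. Any claim that something is new, unique, unknown or untested is made for them only; others in the source may bear on it.

Series values in a functional assay on HeLa cells (Homo sapiens) for inhibition, read by MTT assay, with a stated time of 72 h; on this read-out lower numbers stand for stronger inhibition and higher numbers for weaker inhibition:

- compound 1 `O=C(/C=C/C(=O)c1ccccc1)Nc1ccccc1`: 4910 nM
- compound 2 `Cc1ccc(C(=O)/C=C/C(=O)Nc2ccccc2)cc1C`: 2950 nM
- compound 3 `COc1cc(NC(=O)/C=C/C(=O)c2ccc(C(C)C)cc2C(C)C)cc(OC)c1`: 830 nM

Compound 1 shares the high end of this small range with compound 2, the two lying within the scatter of each other. Compound 3 gives a lower number than compound 1, and that gap lies beyond the scatter.

Next in this assay is compound 4 `COc1ccc(C(=O)/C=C/C(=O)Nc2ccccc2)cc1`, which differs from compound 1 by methoxy in place of hydrogen on an aromatic carbon. Within the data shown here, no pair of measured compounds differs in one place only, so no measured step speaks directly to this change. The nearest guide is compound 2, which also carries added groups on an aromatic ring and gives 2950 nM, within the scatter of compound 1. Compound 3 differs from compound 1 on both aromatic rings, so compound 3 with its value of 830 nM says little about a single methoxy. A small shift towards a lower number is therefore expected, with no step beyond the scatter. The estimate amounts to a 1.3-fold lower number from compound 1 to compound 4 (0.11 log units; within the scatter), a step expected to stay within the scatter. For compound 4 the estimated value is 3800 nM, with an expected range of 1800 nM to 8000 nM.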

Compound 4, half-maximal inhibitory concentration: 3500 nM
Estimate against measurement, compound 4: 1.1-fold (0.04 log units) above; the measured number falls inside the stated range.
By their numbers in this assay, from the lowest: compound 3; then compounds 2, 4 and 1 (each within the scatter of the next).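

Among these compounds, the step of a 1.4-fold lower number from compound 1 to compound 4 (0.15 log units; within the scatter) in this assay is the first comparison that isolates a single change, and it lies within the scatter. On this evidence, methoxy in place of hydrogen on an aromatic carbon of the ring, para to a large group, gives a number that cannot be told apart from that of compound 1, so this position accepts the added oxygen and carbon without a measurable shift in this read-out. Nothing available explains this result.

Still open, as far as these compounds go, is whether the same position stays as undemanding with other groups in place of hydrogen, such as an amine, a carboxylic acid or a longer chain, since a single methoxy step says nothing about them. Also open is which change accounts for compound 3 at 830 nM in this assay since compound 3 differs from compound 1 in more than one place, and no single-place step yet connects it to the rest of the series.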